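A trihydroxyphenyl group replaces the 5-bromo-1H-indol-3-yl group

The source may report more compounds than this note shows. Statements on the series, on what has been measured and on what is new or still open speak of the compounds shown alone.

Measured in a functional assay on DU-145 cells (Homo sapiens) for inhibition, read by trypan blue exclusion, with a stated time of 96 h; on this read-out higher numbers stand for weaker inhibition of growth and lower numbers for stronger inhibition of growth:
- compound 1 `Cc1ccc(CS/C(=C/c2ccc(O)cc2)C(=O)c2ccc(Cl)cc2)cc1` gives 10000 nM
- compound 2 `Cc1ccc(CS/C(=C/c2ccccc2F)C(=O)c2ccc(Cl)cc2)cc1` gives 10000 nM
- compound 3 `Cc1ccc(CS/C(=C/c2c[nH]c3ccc(Br)cc23)C(=O)c2ccc(Cl)cc2)cc1` gives 1000 nM

Compound 3 gives the lowest number of the three (1000 nM), the strongest growth inhibition here. In compound 4 (`Cc1ccc(CS/C(=C/c2ccc(O)c(O)c2O)C(=O)c2ccc(Cl)cc2)cc1`), not yet measured, 2,3,4-trihydroxyphenyl takes the place of 5-bromo-1H-indol-3-yl on a double-bonded chain carbon bound to a double-bonded chain carbon (2,3,4-trihydroxyphenyl in place of 5-bromo-1H-indol-3-yl on a double-bonded chain carbon bound to a double-bonded chain carbon). Among the measured compounds shown here, two measured steps bear on this, read in reverse: bringing in the indolyl group gave modest gains (a 10-fold lower number from compound 1 to compound 3 (1.00 log units; beyond the scatter); a 10-fold lower number from compound 2 to compound 3 (1.00 log units; beyond the scatter)), while exchanging the two phenyl groups gave nothing (no change at the digits printed from compound 1 to compound 2 (within the scatter)). For the measured compounds named here, removing the indolyl group should therefore raise the number in this assay by that size or somewhat less, though no compound carrying 2,3,4-trihydroxyphenyl has been measured. The expected step is modest (a 5.0-fold higher number from compound 3 to compound 4 (0.70 log units; beyond the scatter)). Compound 4 is estimated at 5000 nM (expected range 1500 nM to 15000 nM).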

Compound 4, concentration for 50% growth inhibition: 50000 nM
Estimate against measurement, compound 4: 10-fold (1.00 log units) below; the whole stated range lies below it.
By their numbers in this assay, from the lowest: compound 3; then compounds 1 and 2 (each within the scatter of the next); then compound 4.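

In this assay, this position can weaken growth inhibition as well as strengthen it: swapping 4-hydroxyphenyl for 2-fluorophenyl changed nothing, yet 2,3,4-trihydroxyphenyl gives a 50-fold higher number from compound 3 to compound 4 (1.70 log units; beyond the scatter). It also falls short of both phenyl compounds, with a 5.0-fold higher number from compound 2 to compound 4 (0.70 log units; beyond the scatter) and a 5.0-fold higher number from compound 1 to compound 4 (0.70 log units; beyond the scatter), so the choice of phenyl substituents matters here after all. Nothing available explains this loss.

As far as these compounds go, it remains open whether a phenyl group carrying an amine or a carboxylic acid would fare as poorly as compound 4. Also open, from the compounds shown here alone, is whether an indol-3-yl group without the bromine would keep the gain seen with compound 3.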